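Benzyl for methyl on the piperazine of compound 3

A few compounds are considered here, and "the series" means these few. Any claim that something is new, unique, unknown or untested is made for them only; others in the source may bear on it.

Compound 1 `Cc1ccc2oc(SCC(=O)Nc3ccc(-c4nc(-c5ccccc5)c(-c5ccccc5)n4C)cc3)nc2c1`: 25.6%
Compound 2 `Cn1c(-c2ccc(NC(=O)CSC3=NCCS3)cc2)nc(-c2ccccc2)c1-c1ccccc1`: 31%
Compound 3 `CN1CCN(CC(=O)Nc2ccc(-c3nc(-c4ccccc4)c(-c4ccccc4)n3C)cc2)CC1`: 28.8%

These numbers come from a functional assay on HT-29 cells (Homo sapiens) for cytotoxicity, read by MTT assay, with a stated time of 24 h, tested at 6.4 ug/mL; a higher number here means a stronger effect of the compound at the concentration tested, a lower number a weaker effect. Compound 3 stands within the scatter of both compound 1 and compound 2, so none of the three can be ranked. The measured steps, a number 5.4 percentage points higher from compound 1 to compound 2 (within the scatter), a number 3.2 percentage points higher from compound 1 to compound 3 (within the scatter) and a number 2.2 percentage points lower from compound 2 to compound 3 (within the scatter), all swap the group on the saturated chain carbon bound to the carbonyl carbon and all stay within the scatter. Compound 4 `Cn1c(-c2ccc(NC(=O)CN3CCN(Cc4ccccc4)CC3)cc2)nc(-c2ccccc2)c1-c1ccccc1` differs from compound 3 by phenyl in place of hydrogen on a saturated chain carbon bound to an amine nitrogen in a ring. Within the data shown here, no measured step changes this position, but the neighbouring steps barely moved the number, so no step beyond the scatter is expected: a number 0.2 percentage points higher from compound 3 to compound 4 (within the scatter). Compound 4 is therefore estimated at 29%, ranging from 18% to 40%.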

Compound 4, a percentage reported as activity, at one concentration (the size of the read-out at that concentration, not a potency): 26.8%
The estimate for compound 4 lay 2.2 percentage points above the measured number, and the stated range covers the measured number.
By their numbers in this assay, from the lowest: compounds 1, 4, 3 and 2 (each within the scatter of the next).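

In this assay the change from methyl to benzyl gives a number 2 percentage points lower from compound 3 to compound 4 (within the scatter) and so adding a phenyl at this position produces no readable change. The earlier steps shown here swapped the whole group on the chain carbon, whereas this one alters only the outer end of the piperazine group. No supporting measurement bears on why the number holds. Going by these compounds, whether a carboxylic acid or a longer chain in this place would shift the number beyond the scatter stays open.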